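The compounds below may be only part of what the source reports. "The series", "measured", "known", "first", "only" and "open" are said of these compounds alone.

Measured in a functional assay on NCI-H1975 cells (Homo sapiens) for antiproliferative activity, read by MTT assay, with a stated time of 72 h; a higher number here means a weaker inhibitor, a lower number a stronger inhibitor:
- compound 1 `O=C(Nc1cc(Nc2ccc(Cl)cc2)ncn1)c1ccc(F)cc1`: 17600 nM
- compound 2 `CCOc1ccc(Nc2cc(NC(=O)c3ccccc3)ncn2)cc1`: 7070 nM
- compound 3 `O=C(O)CCC(=O)Nc1cc(Nc2ccc(Cl)cc2)ncn1`: 2730 nM

Compound 3 has the lowest number of the three, and both gaps to it lie beyond the scatter. Compound 4 `Clc1ccc(Nc2cc(Nc3cccc(Cl)n3)ncn2)cc1` has not yet been measured. Its difference from compound 3 is 6-chloropyridin-2-yl in place of (2-carboxyethyl)carbonyl on a nitrogen on an aromatic ring.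

Going by the values given here, only one measured step bears on this, and only loosely. With 2-carboxyethyl in place of 4-fluorophenyl on a carbonyl carbon, the record shows a 6.4-fold lower number from compound 1 to compound 3 (0.81 log units; beyond the scatter), a modest step. Among the compounds with values here, compound 4 also gives up the 2-carboxyethyl chain for an aromatic ring, but it loses the carbonyl too, so no measured step matches the change. In this assay a move to a higher number is therefore expected, probably no larger than that measured step. The expected step is a 2.9-fold higher number from compound 3 to compound 4 (0.47 log units; beyond the scatter). For compound 4 the estimated value is 8000 nM, with an expected range of 2500 nM to 26000 nM.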

Compound 4, half-maximal inhibitory concentration: > 30000 nM
Compound 4: a limit, no number; the forecaster's own chance of this, stated with the estimate: 10%; at least 3.7-fold (0.57 log units) between middle value and limit.
By their numbers in this assay, from the lowest: compound 3; then compound 2; then compound 1. At a limit, above all of these: compound 4.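

In this assay compound 4 stands at a limit and not at a number, the only compound shown there: the limit of > 30000 nM in this assay, at which 1 of the 4 values shown sits. On these data alone, putting 6-chloropyridin-2-yl in place of (2-carboxyethyl)carbonyl on a nitrogen on an aromatic ring gives an at least 10-fold higher number from compound 3 to compound 4 (1.04 log units; beyond the scatter), a large step whose full size stays unknown. Compound 4 is also the only compound shown without a carbonyl on this nitrogen, while compound 1, compound 2 and compound 3 all keep one and all read as numbers.

As far as these compounds go, this change removes the carbonyl and the chain together, so the share of each in the step remains open; a plain acetyl group or a free amine at this nitrogen would bear on that. From the compounds shown here alone, whether the acid end of compound 3 matters is also open, and a methyl ester or a longer chain ending in a carboxylic acid would test it.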